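This account rests on a few compounds, and the source may have more. Where it says the series, first, only, none or still open, it means among the compounds named here.

In a functional assay on SK-OV-3 cells (Homo sapiens) for cytotoxicity, read by MTT assay, with a stated time of 3 days (on this read-out higher numbers stand for weaker inhibition and lower numbers for stronger inhibition), compound 1 `CCNc1nc(SCc2nc3ccccc3[nH]2)nc(-c2ccccc2)c1C#N` gives 7.35 nM, compound 2 `N#Cc1c(Nc2nccs2)nc(SCc2nc3ccccc3[nH]2)nc1-c1ccccc1` gives 5.81 nM and compound 3 `N#Cc1c(NNC(N)=S)nc(SCc2nc3ccccc3[nH]2)nc1-c1ccccc1` gives 3 nM. The data show a 2.5-fold lower number from compound 1 to compound 3 (0.39 log units; beyond the scatter), a modest step, while a 1.9-fold lower number from compound 2 to compound 3 (0.29 log units; within the scatter) and a 1.3-fold lower number from compound 1 to compound 2 (0.10 log units; within the scatter) are both smaller. Compound 3 is thus set apart from only one of the other two.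

Compound 4 `N#Cc1c(NC(N)=O)nc(SCc2nc3ccccc3[nH]2)nc1-c1ccccc1` carries its change at the same place, on a nitrogen on an aromatic ring: a group of 3 heavy atoms (1 carbon, 1 nitrogen, 1 oxygen; no ring) in place of a group of 4 heavy atoms (1 carbon, 2 nitrogen, 1 sulfur; no ring), on a nitrogen on an aromatic ring. Among the measured compounds shown here, all three measured steps alter the group at this place, but none of them brings in carbamoyl, so the data offer no direct precedent. For the measured compounds named here, with compound 2 at 5.81 nM and compound 1 at 7.35 nM as the only guides, a small move toward a higher number is expected in this assay, one that stays within the scatter. The expected step is a 1.7-fold higher number from compound 3 to compound 4 (0.22 log units; within the scatter). For compound 4 the estimate is 5 nM, with an expected range of 1.8 nM to 13 nM.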

Compound 4, half-maximal inhibitory concentration: 6.75 nM
Estimate against measurement, compound 4: 1.4-fold (0.13 log units) below, within the range that was stated.
By their numbers in this assay, from the lowest: compounds 3, 2, 4 and 1 (each within the scatter of the next, the first and the last beyond it).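

In this assay, carbamoyl on a nitrogen on an aromatic ring gives a 2.3-fold higher number from compound 3 to compound 4 (0.35 log units; beyond the scatter), so compound 3 now stands beyond the scatter from a second compound, though it remains within the scatter of compound 2. Carbamoyl is not separated from the other two groups at this place, with a 1.2-fold higher number from compound 2 to compound 4 (0.07 log units; within the scatter) and a 1.1-fold lower number from compound 1 to compound 4 (0.04 log units; within the scatter) both within the scatter, so compounds 1, 2 and 4 cannot be told apart here. Nothing available accounts for the gap between compound 3 and compound 4.

That step removes sulfur and a nitrogen together while bringing in oxygen, so the compounds shown cannot say which part of the exchange goes with the higher number. Going by these compounds, how a plain amine, an acetyl group or a longer alkyl chain on this nitrogen would read in this assay also remains open.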